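A Fluorine Step Repeated on a Methoxy-Bearing Core

A few compounds are considered here, and "the series" means these few. Any claim that something is new, unique, unknown or untested is made for them only; others in the source may bear on it.

Compound 1 `CC(=O)c1cc(-c2ccccc2)cc2cc(-c3ccccc3)[nH]c12` was tested in a functional assay on MCF7 cells (Homo sapiens) for cytotoxicity, read by MTT assay, with a stated time of 2 days, tested at 0.1 uM (on this read-out higher numbers stand for a weaker effect at the one concentration tested and lower numbers for a stronger effect), where compound 1 gives 99.3%. Compound 2 `CC(=O)c1cc(-c2ccc(F)cc2)cc2cc(-c3ccccc3)[nH]c12` carries one change from compound 1, namely (fluoro in place of hydrogen on an aromatic carbon), and in this assay compound 2 gives 98.3%. The move a number 1 percentage points lower from compound 1 to compound 2 (within the scatter) is thus small. Compound 3 `COc1ccc(-c2cc3cc(-c4ccccc4)cc(C(C)=O)c3[nH]2)cc1` instead carries methoxy in place of hydrogen on an aromatic carbon, and in this assay compound 3 gives 87%; the step of a number 12.3 percentage points lower from compound 1 to compound 3 (beyond the scatter) is modest but real, and compound 3 stands lowest of the three measured values. Compound 4 `COc1ccc(-c2cc3cc(-c4ccc(F)cc4)cc(C(C)=O)c3[nH]2)cc1` has not been measured. It differs from compound 3 by fluoro in place of hydrogen on an aromatic carbon, the same change that turns compound 1 into compound 2; this change occurs twice among the compounds shown, each time at the same place. The earlier step of a number 1 percentage points lower from compound 1 to compound 2 (within the scatter) stayed within the scatter. A step of the same small size is expected for compound 4 in this assay: a number 1 percentage points lower from compound 3 to compound 4 (within the scatter). Compound 4 is therefore estimated to give about 86% in this assay, expected to lie between 74% and 98%.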

Compound 4, a percentage reported as activity, at one concentration (the size of the read-out at that concentration, not a potency): 97.3%
The estimate for compound 4 lay 11.3 percentage points below the measured number, and the stated range covers the measured number.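

In this assay, the change from phenyl to 4-fluorophenyl on the methoxy-bearing core gives a number 10.3 percentage points higher from compound 3 to compound 4 (beyond the scatter), whereas on the core of compound 1 the same change stayed within the scatter, yet the two steps cannot be told apart: the same change on two cores in this assay, a number 1 percentage points lower (within the scatter) from compound 1 to compound 2 and a number 10.3 percentage points higher (beyond the scatter) from compound 3 to compound 4, 11.3 percentage points apart, within the scatter of two such steps

Methoxy in place of hydrogen, now on the core that carries the fluoro group, gives a number 1 percentage points lower from compound 2 to compound 4 (within the scatter), and this step likewise cannot be told apart from its earlier counterpart: the same change on two cores in this assay, a number 12.3 percentage points lower (beyond the scatter) from compound 1 to compound 3 and a number 1 percentage points lower (within the scatter) from compound 2 to compound 4, 11.3 percentage points apart, within the scatter of two such steps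

This fits either change carrying over from one core to the other, but it does not prove that each keeps a fixed size, nor does it show that the core alters the effect, since each change is seen only twice and at a single concentration.

The compounds shown leave open how a chloro group, an amine or a carboxylic acid would read in place of the fluoro group. They also leave open whether either change would give a similar step on a further core or at other concentrations.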